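Trimming tert-butyl to isopropyl: what partition might follow

A few compounds are considered here, and "the series" means these few. Any claim that something is new, unique, unknown or untested is made for them only; others in the source may bear on it.

Of the compounds shown here, three on a shared core have been measured in a physicochemical assay for lipophilicity, measured as octanol-water partition; a higher number here means a more lipophilic compound, a lower number a more polar compound. Compound 3 (`CC(C)(C)c1ccc(/C=C/C(=O)N[C@@H]2O[C@H](CO)[C@@H](O)[C@H](O)[C@H]2O)cc1`) stands highest of the three at 0.496. Compound 1 (`O=C(C[C@H](c1ccc(Cl)cc1)C1CC1)N[C@@H]1O[C@H](CO)[C@@H](O)[C@H](O)[C@H]1O`) gives 0.083, and compound 2 (`COC(=O)c1ccc(/C=C/C(=O)N[C@@H]2O[C@H](CO)[C@@H](O)[C@H](O)[C@H]2O)cc1`) gives -0.805. Compound 3 lies beyond the scatter from both.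

The next compound, compound 4 (`CC(C)c1ccc(/C=C/C(=O)N[C@@H]2O[C@H](CO)[C@@H](O)[C@H](O)[C@H]2O)cc1`), differs from compound 3 by one change: hydrogen in place of methyl on a saturated chain carbon bound to an aromatic carbon and two saturated chain carbons. This is hydrogen in place of methyl on a saturated chain carbon bound to an aromatic carbon and two saturated chain carbons, so tert-butyl becomes isopropyl.

Going by the values given here, only one measured step bears on this site, and it does so indirectly: a number 1.30 log units higher from compound 2 to compound 3 (beyond the scatter), with tert-butyl in place of methoxycarbonyl on an aromatic carbon. That large rise involved a different exchange, so it cannot set the size of the new step. Among the compounds with values here, no measured step isolates the loss of a methyl. Compound 4 keeps most of the tert-butyl group, so only a small fall in this assay is expected, close to the edge of the scatter. The expected change is a number 0.35 log units lower from compound 3 to compound 4 (beyond the scatter). For compound 4 the estimated value is 0.15, with an expected range of -0.15 to 0.45.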

Compound 4, partition coefficient: 0.296
Compound 4: middle estimate off by 0.15 log units, on the low side; the range from low to high includes it.
By their numbers in this assay, from the lowest: compound 2; then compounds 1, 4 and 3 (each within the scatter of the next, the first and the last beyond it).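

In this assay, going by these compounds alone, hydrogen in place of methyl on this saturated chain carbon gives a number 0.20 log units lower from compound 3 to compound 4 (within the scatter) and so, for the first time, isolates this single methyl; on this evidence, the tert-butyl and isopropyl compounds cannot be told apart. Measured against methoxycarbonyl on the same aromatic carbon, isopropyl gives a number 1.10 log units higher from compound 2 to compound 4 (beyond the scatter) and tert-butyl gives a number 1.30 log units higher from compound 2 to compound 3 (beyond the scatter), so both exchanges are printed as large and beyond the scatter, while the trimming of tert-butyl to isopropyl is not. Nothing in the available evidence accounts for either the large steps or the one within the scatter.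

The compounds shown leave open how the partition reading would respond if this aromatic carbon carried an ethyl group, a longer chain, an amine or a carboxylic acid. They also leave open whether hydrogen in place of methyl would stay within the scatter if a further methyl were removed from isopropyl, or if the same exchange were made on a different core.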